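The source may report more compounds than this note shows. Statements on the series, on what has been measured and on what is new or still open speak of the compounds shown alone.

Measured compounds:
- compound 1, `Brc1cncc(N2CC[C@H]3CN[C@H]3C2)c1`: 76 nM
- compound 2, `COc1cncc(N2CC[C@H]3CN[C@H]3C2)c1`: 180 nM

In a functional assay on HEK293 cells for agonist activity at Neuronal acetylcholine receptor; alpha3/beta4 (Homo sapiens), read by FLIPR (a higher number here means that more compound is needed for the effect, a lower number that less compound is needed), compound 2 gives the higher of the two numbers, set apart from compound 1 by a 2.4-fold higher number from compound 1 to compound 2 (0.37 log units; beyond the scatter).

Compound 3, `CCOc1cncc(N2CC[C@H]3CN[C@H]3C2)c1`, is not yet measured; it carries methyl in place of hydrogen on a saturated chain carbon bound to an oxygen on an aromatic ring. Among the measured compounds shown here, the only recorded step swaps one aromatic substituent for another rather than extending the methoxy, so it bears on this change only loosely; no step shows what adding a carbon at this place does. With that, a small move in this assay or none beyond the scatter is the expectation. For compound 3 the estimated value is 220 nM, range 100 nM to 500 nM, an expected step of a 1.2-fold higher number from compound 2 to compound 3 (0.09 log units; within the scatter).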

Compound 3, half-maximal effective concentration: 124 nM
For compound 3 the middle estimate is 1.8-fold (0.25 log units) above the measured one; the measured number falls inside the stated range.
By their numbers in this assay, from the lowest: compounds 1, 3 and 2 (each within the scatter of the next, the first and the last beyond it).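

In this assay, among the compounds shown here, the first change of chain length at this place, methoxy to ethoxy, gives a 1.5-fold lower number from compound 2 to compound 3 (0.16 log units; within the scatter) and so leaves the number unchanged within the scatter. Ethoxy in place of bromo gives a 1.6-fold higher number from compound 1 to compound 3 (0.21 log units; within the scatter) and, unlike methoxy, is not set apart from bromo beyond the scatter. No supporting measurement bears on this result.

Still open, as far as these compounds go, is whether a longer chain such as propoxy, or a branched isopropoxy, stays within the scatter of ethoxy. An amine at this aromatic carbon also remains an untested comparison within the compounds shown.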